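The source may report more compounds than this note shows. Statements on the series, on what has been measured and on what is new or still open speak of the compounds shown alone.

Compound 3 `CS(=O)(=O)c1ccc(Cc2n[nH]c(=S)n2/N=C/c2ccc(F)cc2)cc1` carries a 4-fluorophenyl group on the carbon with a double bond to nitrogen; in a functional assay on HeLa cells (Homo sapiens) for cytotoxicity, read by MTT assay, with a stated time of 48 h, tested at 25 uM (on this read-out higher numbers stand for a stronger effect at the one concentration tested and lower numbers for a weaker effect), compound 3 was reported as "not active" (no number reported), with no number. Its neighbours on the shared core are compound 1 `CS(=O)(=O)c1ccc(Cc2n[nH]c(=S)n2/N=C/c2cccnc2)cc1`, which in this assay gives 19.4%, and compound 2 `CS(=O)(=O)c1ccc(Cc2n[nH]c(=S)n2/N=C/c2ccc(Cl)cc2)cc1`, which gives 47.5%; the step of a number 28.1 percentage points higher from compound 1 to compound 2 (beyond the scatter) concerns a different part of the molecule. Compound 4 `CS(=O)(=O)c1ccc(Cc2n[nH]c(=S)n2/N=C/c2ccccc2F)cc1` differs from compound 3 only by 2-fluorophenyl in place of 4-fluorophenyl on a carbon with a double bond to nitrogen. Among the measured compounds shown here, no measured step follows this change, so the reading of compound 3 is the main guide. Compound 4 is therefore expected to stay weak in this assay, estimated at 12%, within 0% to 30%.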

Compound 4, a percentage reported as activity, at one concentration (the size of the read-out at that concentration, not a potency): 14%
Compound 4: middle estimate off by 2 percentage points, on the low side; measured number inside the range.
By their numbers in this assay, from the lowest: compounds 4 and 1 (each within the scatter of the next); then compound 2.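

At this position, this assay shows a number 33.5 percentage points lower from compound 2 to compound 4 (beyond the scatter), while a number 5.4 percentage points lower from compound 1 to compound 4 (within the scatter), so 2-fluorophenyl gives a reading level with pyridin-3-yl and well short of 4-chlorophenyl. Compound 3 has no number, so the step from it to compound 4 cannot be read. Nothing at hand explains these differences.

Still open, from the compounds shown here alone, is whether the gain seen with 4-chlorophenyl belongs to chlorine itself or to where it sits on the ring, which 2-chlorophenyl could test. Also open, going by these compounds, is how a phenyl ring carrying an amine or a carboxylic acid would read on this carbon.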